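The source may report more compounds than this note shows. Statements on the series, on what has been measured and on what is new or still open speak of the compounds shown alone.

Working notes on the aryl series. All compounds share the core of compound 1 `C/C(=C\CC/C(C)=C/CC[C@@H]1[C@@]2(C)CCC(=O)C(C)(C)[C@H]2CC[C@@]1(C)O)CC/C=C(\C)C(=O)OCc1cn(-c2ccc(F)cc2)nn1`, which differs among them only in the aryl group on an aromatic nitrogen, and all are read in a functional assay on A549 cells (Homo sapiens) for antiproliferative activity, read by MTT assay, with a stated time of 48 h; a lower number here means a stronger inhibitor, a higher number a weaker inhibitor. Compound 1 returns only a limit of this assay, > 150000 nM. Compound 2 `C/C(=C\CC/C(C)=C/CC[C@@H]1[C@@]2(C)CCC(=O)C(C)(C)[C@H]2CC[C@@]1(C)O)CC/C=C(\C)C(=O)OCc1cn(-c2ccc(C)cc2)nn1` likewise returns only a limit, > 150000 nM. Within the data shown here, compound 3 `C/C(=C\CC/C(C)=C/CC[C@@H]1[C@@]2(C)CCC(=O)C(C)(C)[C@H]2CC[C@@]1(C)O)CC/C=C(\C)C(=O)OCc1cn(-c2cccc(F)c2)nn1`, with 3-fluorophenyl on the aromatic nitrogen, gives 124000 nM and stands as the only true number in the set. The step that the two limits leave unreadable from compound 1 to compound 2. The steps of an at least 1.2-fold lower number from compound 1 to compound 3 (0.08 log units; that floor lies within the scatter) and an at least 1.2-fold lower number from compound 2 to compound 3 (0.08 log units; that floor lies within the scatter) are floors fixed by the limit of > 150000 nM in this assay, at which 2 of the 3 values shown sit, so no change of the aryl group so far has moved the read-out beyond the scatter.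

Compound 4 `C/C(=C\CC/C(C)=C/CC[C@@H]1[C@@]2(C)CCC(=O)C(C)(C)[C@H]2CC[C@@]1(C)O)CC/C=C(\C)C(=O)OCc1cn(-c2ccccc2Br)nn1` has not yet been measured. The change is 2-bromophenyl in place of 3-fluorophenyl on an aromatic nitrogen. Both measured steps that touch the aryl group are unreadable or sit within the scatter, so no step beyond the scatter is expected in this assay, in either direction. The step from compound 3 is expected to be a 1.1-fold higher number from compound 3 to compound 4 (0.05 log units; within the scatter). Compound 4 is therefore estimated at 140000 nM, with a range from 60000 nM to 300000 nM, and a real chance that only a limit is reported.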

Compound 4, half-maximal inhibitory concentration: > 150000 nM
Compound 4 ended at the assay's limit; the forecaster's own chance of this, stated with the estimate: 45%; middle value at least 1.0-fold (0.02 log units) away from the limit.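

In this assay, the 2-bromophenyl group brings a bromine and a new place on the aryl ring into the series, and the read-out gives an at least 1.2-fold higher number from compound 3 to compound 4 (0.08 log units; that floor lies within the scatter). The steps from compound 1 and from compound 2 to compound 4 cannot be read. A change of both the halogen and its place on the aryl group thus adds no step beyond the scatter, and the series stays tied to one bound: the limit of > 150000 nM in this assay, at which 3 of the 4 values shown sit.

Whether any group on the aromatic nitrogen can bring the read-out well clear of that limit stays open, as the aryl groups shown carry only fluoro, methyl or bromo on the phenyl, and an amine or a carboxylic acid on the phenyl could behave differently. Also open, going by these compounds, is whether a change outside the aryl group, such as an amide in place of the ester, would give true numbers that allow the aryl steps to be sized.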